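Removing the methoxy from the benzyl arm of compound 3

The source may report more compounds than this note shows. Statements on the series, on what has been measured and on what is new or still open speak of the compounds shown alone.

Values in an assay on isolated protein for inhibition of G protein-coupled receptor kinase 6 (Homo sapiens), read by scintillation counting, radiometric assay and 33P incorporation, with a stated time of 80 min, in the presence of a further agent that is not named here; a higher number here means a weaker inhibitor, a lower number a stronger inhibitor:
compound 1 `CCc1cc(Nc2nc(N[C@@H](C)c3ccc(F)cn3)nc3cccc(C)c23)n[nH]1`: 11 nM
compound 2 `CCc1cc(Nc2nc(NCc3ccc(Cl)cc3)nc3cccc(OC)c23)n[nH]1`: 16 nM
compound 3 `CCc1cc(Nc2nc(NCc3ccc(Cl)cc3OC)nc3cccc(C)c23)n[nH]1`: 6 nM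

Compound 3 gives the lowest of the three numbers in this assay; compound 1 sits within the scatter of it, compound 2 beyond it. Compound 4 `CCc1cc(Nc2nc(NCc3ccc(Cl)cc3)nc3cccc(C)c23)n[nH]1` differs from compound 3 by hydrogen in place of methoxy on an aromatic carbon. Going by the values given here, the only single-point step measured, a 1.8-fold lower number from compound 1 to compound 3 (0.26 log units; within the scatter), swaps the whole benzyl arm and says nothing specific about the methoxy. Among the compounds with values here, compound 2 carries the same 4-chlorobenzyl as compound 4 but on a core bearing methoxy rather than methyl; its number lies above that of compound 3, with no measured step between the two. The expected step of a 2.0-fold higher number from compound 3 to compound 4 (0.30 log units; within the scatter) is therefore modest, toward a somewhat higher number, probably within the scatter. Compound 4 is estimated at 12 nM, range 5 nM to 30 nM.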

Compound 4, half-maximal inhibitory concentration: 27 nM
The estimate for compound 4 lay 2.3-fold (0.35 log units) below the measured number; the range from low to high includes it.
By their numbers in this assay, from the lowest: compounds 3, 1, 2 and 4 (each within the scatter of the next, the first and the last beyond it).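

Going by these compounds alone, removing the methoxy from the 4-chloro-2-methoxybenzyl arm gives a step beyond the scatter in this assay (a 4.5-fold higher number from compound 3 to compound 4 (0.65 log units; beyond the scatter)), the first reading of this group on its own. With the 4-chlorobenzyl arm, the change on the core stays within the scatter (a 1.7-fold higher number from compound 2 to compound 4 (0.23 log units; within the scatter)), whereas replacing the 1-(5-fluoropyridin-2-yl)ethyl group with 4-chlorobenzyl lies beyond it (a 2.5-fold higher number from compound 1 to compound 4 (0.39 log units; beyond the scatter)). Nothing here accounts for the methoxy step.

Hydroxy, ethoxy or fluoro at this place would test whether the oxygen or the whole methoxy carries the step. On these data alone, whether the step holds on the core of compound 2 remains open.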